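Shifting the methoxy group on the aryl ketone of compound 1

A few compounds are considered here, and "the series" means these few. Any claim that something is new, unique, unknown or untested is made for them only; others in the source may bear on it.

Compound 1, with the structure `COc1cccc(C(=O)c2ccc3c(ccn3S(=O)(=O)c3cccc(/C=C/C(=O)NO)c3)c2)c1`, was examined in an assay on isolated protein for inhibition of protein deacetylase HDAC6 (Homo sapiens) (on this read-out higher numbers stand for weaker inhibition and lower numbers for stronger inhibition), and gave 1810 nM. Among the two compounds measured so far, compound 1 stands at the highest number. The other, compound 2, built as `O=C(NO)c1ccc(Cn2ccc3cc(C(=O)c4ccc(Cl)cc4)ccc32)cc1`, gave 6.73 nM in this assay, a value that lies well beyond the usual scatter from that of compound 1; the two structures differ in many places at once, so only the two values themselves can be compared.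

The next compound, compound 3, has the structure `COc1ccc(C(=O)c2ccc3c(ccn3S(=O)(=O)c3cccc(/C=C/C(=O)NO)c3)c2)cc1`. It differs from compound 1 in one place: 4-methoxyphenyl in place of 3-methoxyphenyl on a carbonyl carbon. The same atoms are present in both, only joined differently.

Among the compounds with values here, no measured pair with this kind of change exists here, so the step from compound 1 to compound 3 can only be estimated. Compound 3 is expected to remain close to compound 1, with a step of a 1.2-fold lower number from compound 1 to compound 3 (0.08 log units; within the scatter) that need not exceed the scatter in either direction. Compound 3 is estimated at 1500 nM in this assay, in a range from 500 nM to 5000 nM.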

Compound 3, half-maximal inhibitory concentration: 751 nM
The estimate for compound 3 lay 2.0-fold (0.30 log units) above the measured number; the range from low to high includes it.
By their numbers in this assay, from the lowest: compound 2; then compound 3; then compound 1.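

In this assay, moving the methoxy group so that 4-methoxyphenyl replaces 3-methoxyphenyl on a carbonyl carbon gives a 2.4-fold lower number from compound 1 to compound 3 (0.38 log units; beyond the scatter), a modest step but one that lies beyond the scatter. This shows that the number at this place responds to the arrangement of the methoxy group alone, since the same atoms are present in both compounds and the shared core and the hydroxamic acid end stay unchanged. Within the data shown here, the earlier comparison could not show this, as compound 1 and compound 2 differ in many places at once, whereas this is the first step that isolates a single change, and nothing available bears on what lies behind it.

Going by these compounds, it remains open whether the step reflects the methoxy group specifically or would also appear with another group at the same place on the phenyl ring, such as a hydroxyl, an amine or a carboxylic acid. On these data alone, it is also open whether the same change would have a comparable effect on a different core, such as that of compound 2.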